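Replacing the 2-(pyrrolidin-1-yl)ethyl Chain: A Forecast

The source may report more compounds than this note shows. Statements on the series, on what has been measured and on what is new or still open speak of the compounds shown alone.

Three compounds share one core and have been studied in a functional assay on the whole organism (blood, strain Sprague-Dawley albino) with Rattus norvegicus as the target, with stated times of 30 min and 5 h, at a dose of 100 mg/kg by the oral route; a lower number here means less inhibition, a higher number more inhibition at the dose given (going by the name of the read-out):
- compound 1 `COc1ccc(-c2cc(-c3ccccc3)no2)c(OCC(O)CN2CCCCC2)c1` gives 15.8%
- compound 2 `COc1ccc(-c2cc(-c3ccccc3)no2)c(OCCCN2CCCC2)c1` gives 13.4%
- compound 3 `CCOC(=O)CCCOc1cc(OC)ccc1-c1cc(-c2ccccc2)no1` gives "not determined" (no result reported), that is, no result reported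

Among the measured compounds shown here, compound 2 holds the lower of the two numbers, with compound 1 as its only neighbour; the step of a number 2.4 percentage points lower from compound 1 to compound 2 (within the scatter) lies within the scatter, so the two cannot be told apart. Compound 3 adds nothing to the comparison.

Compound 4 `CCN(CC)CC(O)COc1cc(OC)ccc1-c1cc(-c2ccccc2)no1` differs from compound 2 in one place:
2-(diethylamino)-1-hydroxyethyl in place of 2-(pyrrolidin-1-yl)ethyl on a saturated chain carbon bound to an oxygen on an aromatic ring

For the measured compounds named here, only one measured step touches this region of the molecule. It exchanges 1-hydroxy-2-(piperidin-1-yl)ethyl for 2-(pyrrolidin-1-yl)ethyl at the same place, and it came out as a number 2.4 percentage points lower from compound 1 to compound 2 (within the scatter), within the scatter. Compound 4 carries a 2-(diethylamino)-1-hydroxyethyl group, which, unlike the groups at this place in compound 1 and compound 2, contains no ring. Going by the values given here, because the only comparable step a number 2.4 percentage points lower from compound 1 to compound 2 (within the scatter) did not move the read-out, no shift beyond the scatter is expected from compound 2 to compound 4. The expected step is a number 1.6 percentage points higher from compound 2 to compound 4 (within the scatter). Compound 4 is therefore estimated at 15%, with a likely range from 5% to 25%.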

Compound 4, a percentage reported as inhibition, in the whole organism at one dose (the size of the read-out at that dose, not a potency): 11.6%
Estimate against measurement, compound 4: 3.4 percentage points above, within the range that was stated.
By their numbers in this assay, from the lowest: compounds 4, 2 and 1 (each within the scatter of the next).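

Three different amine ends now sit on this chain, and in this assay none of the exchanges separates two compounds. Swapping 3-(pyrrolidin-1-yl)propyl for 3-(diethylamino)-2-hydroxypropyl removes the ring and adds a hydroxyl group, yet it gives a number 1.8 percentage points lower from compound 2 to compound 4 (within the scatter), and with the hydroxyl group kept in place, diethylamino in place of piperidin-1-yl gives a number 4.2 percentage points lower from compound 1 to compound 4 (within the scatter), so at this position a ring in the amine is not required to hold the read-out at this level. No supporting measurement is available to explain why these exchanges leave the number within the scatter.

All three numbers were taken at a single oral dose, so they show the size of the read-out at that dose and say nothing about how potency compares across the amines. As far as these compounds go, it remains open whether a morpholin-4-yl group, a carboxylic acid at the end of the chain, or a longer chain between the oxygen and the amine would move the number beyond the scatter.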